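The source may report more compounds than this note shows. Statements on the series, on what has been measured and on what is new or still open speak of the compounds shown alone.

Series values in a functional assay on SW620/5-FU cells (Homo sapiens) for cytotoxicity, read by MTT assay, with a stated time of 48 h, in the presence of a further agent that is not named here; a higher number here means that more compound is needed for the effect, a lower number that less compound is needed:
- compound 1 `Cc1nn(C)c2nc(NNC(=O)Nc3cc(Cl)nc(Cl)c3)cc(C3CC3)c12` gives 80800 nM
- compound 2 `COc1ccc(-c2cc(NNC(=O)Nc3cc(Cl)nc(Cl)c3)nc3c2c(C)nn3C)cc1` gives 9700 nM
- compound 3 `Cc1nn(C)c2nc(NNC(=O)Nc3cc(Cl)nc(Cl)c3)cc(-c3ccc(Cl)s3)c12` gives 29400 nM

Compound 3 holds the middle place of the three numbers. On one side lies a 2.7-fold lower number from compound 1 to compound 3 (0.44 log units; beyond the scatter), and on the other lies a 3.0-fold higher number from compound 2 to compound 3 (0.48 log units; beyond the scatter). Both gaps are modest.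

The next compound is compound 4 `Cc1nn(C)c2nc(NNC(=O)Nc3cc(Cl)nc(Cl)c3)cc(-c3ccc(F)cc3)c12`, which has 4-fluorophenyl in place of 5-chlorothiophen-2-yl on an aromatic carbon. Among the compounds with values here, no measured step makes this exact exchange, so the evidence is indirect. Within the data shown here, the closest comparison is compound 2, the only measured compound with a six-membered aromatic ring of carbon only at this place, and the relevant step is again a 3.0-fold higher number from compound 2 to compound 3 (0.48 log units; beyond the scatter). The change from the cyclopropyl compound to an aryl group also bears on it, as an 8.3-fold lower number from compound 1 to compound 2 (0.92 log units; beyond the scatter) and the smaller step to compound 3 both lowered the number. With three values, and a fluorine rather than a methoxy group on the phenyl ring, this is weak guidance.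

A modest fall in this assay is therefore expected, leaving compound 4 roughly between compound 2 and compound 3. The estimated step is a 2.1-fold lower number from compound 3 to compound 4 (0.32 log units; beyond the scatter). The estimated value for compound 4 is 14000 nM, with an expected range from 5500 nM to 36000 nM.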

Compound 4, half-maximal effective concentration: 17400 nM
For compound 4 the middle estimate is 1.2-fold (0.09 log units) below the measured one; low and high end bracket the measured number.
By their numbers in this assay, from the lowest: compounds 2, 4 and 3 (each within the scatter of the next, the first and the last beyond it); then compound 1.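

In this assay, 4-fluorophenyl in place of 5-chlorothiophen-2-yl gives a 1.7-fold lower number from compound 3 to compound 4 (0.23 log units; within the scatter), and fluoro in place of methoxy on the phenyl ring gives a 1.8-fold higher number from compound 2 to compound 4 (0.25 log units; within the scatter), so compound 4 cannot be separated from either neighbour, even though a 3.0-fold higher number from compound 2 to compound 3 (0.48 log units; beyond the scatter) keeps those two neighbours apart. The comparison with the cyclopropyl compound is clearer, at a 4.6-fold lower number from compound 1 to compound 4 (0.67 log units; beyond the scatter), which makes compound 4 the third compound with an aromatic ring on this carbon to lie beyond the scatter from compound 1, with none of the compounds shown going against that pattern. No measured information on these compounds accounts for either the small or the larger steps.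

The two phenyl compounds leave open whether any group on the phenyl ring matters here, as the only exchange shown, fluoro for methoxy, stays within the scatter, and a plain phenyl, a trifluoromethyl or a nitrile on that ring would test this further. Also open, from the compounds shown here alone, is how non-aromatic groups other than cyclopropyl behave on this carbon, such as an amine, a carboxylic acid or a longer alkyl chain.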